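The source may report more compounds than this note shows. Statements on the series, on what has been measured and on what is new or still open speak of the compounds shown alone.

Compound 1, `COc1ccc2c(/C=C/C(=O)c3cc(OC)c(OC)c(SC)c3)c[nH]c2c1`, was tested in a functional assay on MCF7 cells (Homo sapiens) for antiproliferative activity, read by MTT assay, with a stated time of 48 h (on this read-out higher numbers stand for weaker inhibition and lower numbers for stronger inhibition), where compound 1 gives 101 nM. Compound 2, `COc1ccc2c(/C=C/C(=O)c3cc(OC)c(OC)c(SC)c3)cn(C)c2c1`, carries one change from compound 1, (methyl in place of hydrogen on an aromatic nitrogen), and in this assay compound 2 gives 166 nM; the step is a 1.6-fold higher number from compound 1 to compound 2 (0.22 log units; within the scatter). Compound 3, `COc1cc(C(=O)/C(C)=C/c2c[nH]c3ccccc23)cc([Se]C)c1OC`, has a different core, and the difference between the two cores is not broken down here. In this assay compound 3 gives 59 nM. For the measured compounds named here, compound 4, `COc1cc(C(=O)/C(C)=C/c2cn(C)c3ccccc23)cc([Se]C)c1OC`, has not yet been measured and differs from compound 3 by methyl in place of hydrogen on an aromatic nitrogen, the same change as the one from compound 1 to compound 2. Going by the values given here, the step is expected to be a 1.6-fold higher number from compound 3 to compound 4 (0.21 log units; within the scatter), beside the earlier 1.6-fold higher number from compound 1 to compound 2 (0.22 log units; within the scatter), because a 1.6-fold higher number from compound 1 to compound 2 (0.22 log units; within the scatter) is the only measured example of this change. Compound 4 is therefore estimated to give 95 nM.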

Compound 4, half-maximal inhibitory concentration: 77 nM
Estimate against measurement, compound 4: 1.2-fold (0.09 log units) above; low and high end bracket the measured number.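

In this assay, methyl in place of hydrogen on an aromatic nitrogen gives a 1.3-fold higher number from compound 3 to compound 4 (0.12 log units; within the scatter), and the two steps can be compared directly: the same change on two cores in this assay, a 1.6-fold higher number (0.22 log units; within the scatter) from compound 1 to compound 2 and a 1.3-fold higher number (0.12 log units; within the scatter) from compound 3 to compound 4, 1.3-fold (0.10 log units) apart, within the scatter of two such steps. In these two pairs, then, the change behaves alike on both cores, and the step seen on one core was a fair guide to the step on the other. It does not show that the methyl itself shifts the number, as neither step stands clear of the scatter, and two pairs say nothing about other cores.

From the compounds shown here alone, what an ethyl group, a longer chain or a chain ending in an amine would do on that same nitrogen stays open. So does whether any such group would give a step beyond the scatter.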